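The source may report more compounds than this note shows. Statements on the series, on what has been measured and on what is new or still open speak of the compounds shown alone.

Measured so far:
- compound 1 `CCCNC(=O)c1ccc(C#Cc2cccc(F)c2)cn1`, 65.9%
- compound 2 `CC(C)(O)CNC(=O)c1ccc(C#Cc2cccc(F)c2)cn1`, 61.5%

Among the compounds with values here, in a functional assay on HEK293 cells for positive allosteric modulation of metabotropic glutamate receptor 5 (Rattus norvegicus), read by fluorescence and calcium flux (on this read-out higher numbers stand for larger maximal responses and lower numbers for smaller maximal responses), compound 2 gives 61.5%; the only other number is that of compound 1 at 65.9%, and the step of a number 4.4 percentage points lower from compound 1 to compound 2 (within the scatter) lies within the scatter. Compound 3 `CC(C)(O)CCNC(=O)c1ccc(C#Cc2cccc(F)c2)cn1` differs from compound 2 as follows: 2-hydroxy-2-methylpropyl in place of 1-hydroxy-1-methylethyl on a saturated chain carbon bound to an amide-type nitrogen. Within the data shown here, the only step that bears on this, a number 4.4 percentage points lower from compound 1 to compound 2 (within the scatter), changed the group on the same saturated chain carbon and stayed within the scatter, so for this assay no change beyond the scatter is expected, a number 1.5 percentage points lower from compound 2 to compound 3 (within the scatter). Compound 3 is estimated at 60%, within 45% to 75%.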

Compound 3, largest response reached (reported as efficacy), in percent of the reference or control that the assay uses: 61.9%
Beside the measured number, compound 3's estimate is 1.9 percentage points below it; measured number inside the range.
By their numbers in this assay, from the lowest: compounds 2, 3 and 1 (each within the scatter of the next).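

In this assay, 2-hydroxy-2-methylpropyl in place of 1-hydroxy-1-methylethyl on a saturated chain carbon bound to an amide-type nitrogen gives a number 0.4 percentage points higher from compound 2 to compound 3 (within the scatter), so the longer hydroxylated chain does not separate from the shorter one. The comparison with the unhydroxylated chain gives a number 4 percentage points lower from compound 1 to compound 3 (within the scatter), so three chains at this position now sit within the scatter of one another. No supporting data bear on the reason for this result.

As far as these compounds go, whether an amine, a carboxylic acid or a ring at this position would give a step beyond the scatter remains open.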